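A few compounds are considered here, and "the series" means these few. Any claim that something is new, unique, unknown or untested is made for them only; others in the source may bear on it.

Of the compounds shown here, two have numbers so far in a functional assay on A549 cells (Homo sapiens) for antiproliferative activity, read by MTT assay, with a stated time of 48 h (a higher number here means a weaker inhibitor, a lower number a stronger inhibitor), and their values can be compared directly. Compound 1 (`O=C(/C=C/c1ccccc1)Nc1nnc(-c2ccc(Br)cc2)s1`) gives 2.18 ug/mL and compound 2 (`COc1ccc(/C=C/C(=O)Nc2nnc(-c3ccc(Cl)cc3)s2)cc1`) gives 1.38 ug/mL there. These two values lie within the usual scatter of repeated measurements, so compound 2 stands level with compound 1 on present evidence.

Compound 3 (`COc1ccc(/C=C/C(=O)Nc2nnc(-c3ccc(Br)cc3)s2)cc1`) is still unmeasured. It comes from compound 2 by one small edit, counted as bromo in place of chloro on an aromatic carbon in full: bromo in place of chloro on an aromatic carbon, para to a large group. Cut one bond further out, 4-chlorophenyl becomes 4-bromophenyl. Among the compounds with values here, no measured pair shows this swap alone, so the evidence is indirect. Compound 1 already carries 4-bromophenyl, and its 2.18 ug/mL sits within the scatter of the value for compound 2, although the two also differ elsewhere.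

No step beyond the scatter is therefore expected in this assay for this swap. The estimated step is a 1.2-fold higher number from compound 2 to compound 3 (0.06 log units; within the scatter) and it is expected to stay within the scatter. Compound 3 is expected to give about 1.6 ug/mL with an estimated range from 0.7 ug/mL to 3.5 ug/mL in this measurement.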

Compound 3, half-maximal inhibitory concentration: 1.04 ug/mL
The estimate for compound 3 lay 1.5-fold (0.19 log units) above the measured number; low and high end bracket the measured number.
By their numbers in this assay, from the lowest: compounds 3, 2 and 1 (each within the scatter of the next, the first and the last beyond it).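

In this assay the swap of 4-chlorophenyl for 4-bromophenyl, with the halogen on an aromatic carbon para to a large group, gives a 1.3-fold lower number from compound 2 to compound 3 (0.12 log units; within the scatter) and so shows that, with the methoxy group present, chloro and bromo cannot be told apart at this position. Within the data shown here, the clearer signal comes from the other change, methoxy in place of hydrogen on an aromatic carbon with the 4-bromophenyl group held fixed, which gives a 2.1-fold lower number from compound 1 to compound 3 (0.32 log units; beyond the scatter) and is the only single-place step here that clears the scatter, though only modestly and in a single pair of compounds. Nothing at hand gives a measured property or other data that could explain either step.

Still open, on these data alone, is whether this halogen position would respond to a different kind of group, such as fluoro, trifluoromethyl or an amine, since chloro and bromo are close relatives and span little of what could sit there. Also open, as far as these compounds go, is whether the methoxy step carries over to the 4-chlorophenyl series, and whether ethoxy or hydroxy in the methoxy position would give a similar number.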